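The source may hold more compounds than are shown below. What is called first, only, known or untested is meant among the compounds shown, and "the series" means these compounds.

In a functional assay on HeLa cells (Homo sapiens) for cytotoxicity, read by MTT assay, with a stated time of 72 h (on this read-out higher numbers stand for weaker inhibition and lower numbers for stronger inhibition), compound 3 `COc1cc(/C=C/C(=O)Nc2cc3c(Nc4ccc(F)c(Cl)c4)ncnc3cc2O[C@H]2CCOC2)cc(OC)c1OC` gives 24500 nM, level within the scatter with compound 1 `O=C(/C=C/c1ccc([N+](=O)[O-])cc1)Nc1cc2c(Nc3ccc(F)c(Cl)c3)ncnc2cc1O[C@H]1CCOC1` at 27400 nM. For compound 2 `COc1ccc(OC)c(/C=C/C(=O)Nc2cc3c(Nc4ccc(F)c(Cl)c4)ncnc3cc2OC)c1`, which carries the 2,5-dimethoxyphenyl on a different core, the entry reads "not determined" (no result reported), so it offers no guide. Compound 4 `COc1ccc(OC)c(/C=C/C(=O)Nc2cc3c(Nc4ccc(F)c(Cl)c4)ncnc3cc2O[C@H]2CCOC2)c1` departs from compound 3 as follows: 2,5-dimethoxyphenyl in place of 3,4,5-trimethoxyphenyl on a double-bonded chain carbon bound to a double-bonded chain carbon. The change is 2,5-dimethoxyphenyl in place of 3,4,5-trimethoxyphenyl on a double-bonded chain carbon bound to a double-bonded chain carbon. Within the data shown here, the only measured step bearing on this, a 1.1-fold lower number from compound 1 to compound 3 (0.05 log units; within the scatter), exchanged the group at that same place and stayed within the scatter. No step beyond the scatter is therefore expected in this assay, and the estimated step is a 1.0-fold higher number from compound 3 to compound 4 (0.01 log units; within the scatter). For compound 4 the expected value is 25000 nM, with an estimated range of 12000 nM to 50000 nM.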

Compound 4, half-maximal inhibitory concentration: 26800 nM
Beside the measured number, compound 4's estimate is 1.1-fold (0.03 log units) below it; low and high end bracket the measured number.
By their numbers in this assay, from the lowest: compounds 3, 4 and 1 (each within the scatter of the next).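

In this assay, 2,5-dimethoxyphenyl at this place, on a double-bonded chain carbon bound to a double-bonded chain carbon, makes little difference against either earlier group: 3,4,5-trimethoxyphenyl (a 1.1-fold higher number from compound 3 to compound 4 (0.04 log units; within the scatter)) and 4-nitrophenyl (a 1.0-fold lower number from compound 1 to compound 4 (0.01 log units; within the scatter)). The three aromatic groups shown are therefore not separated by this read-out, and a different methoxy arrangement adds no step beyond the scatter. No measurement available here offers an explanation for this result. From the compounds shown here alone, it remains open whether an amine or a carboxylic acid on this phenyl ring would give a step beyond the scatter, and a longer chain between the amide carbonyl and the ring is equally untested by these compounds.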